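Methoxy on the Phenyl Ring of a Pyrazolopyridine Urea

A few compounds are considered here, and "the series" means these few. Any claim that something is new, unique, unknown or untested is made for them only; others in the source may bear on it.

Compound 1 `Cn1ncc2c(-c3ccccc3)cc(NNC(=O)Nc3cc(Cl)nc(Cl)c3)nc21`: 6240 nM
Compound 2 `Cn1ncc2c(-c3ccc(F)cc3)cc(NNC(=O)Nc3cc(Cl)cc(Cl)c3)nc21`: 39100 nM
Compound 3 `Cn1nc(C(F)(F)F)c2c(-c3ccccc3)cc(NNC(=O)Nc3cc(Cl)nc(Cl)c3)nc21`: 18100 nM

In a functional assay on HCT-116 cells (Homo sapiens) for cytotoxicity, read by MTT assay, with a stated time of 48 h, in the presence of a further agent that is not named here (a higher number here means that more compound is needed for the effect, a lower number that less compound is needed), compound 1 gives the lowest of the three numbers. For the measured compounds named here, the one measured single change, a 2.9-fold higher number from compound 1 to compound 3 (0.46 log units; beyond the scatter), concerns a different part of the shared core and is a modest rise. Compound 2 carries two changes at once and is weaker still, but it does not isolate the phenyl substituent. Compound 4 `COc1ccc(-c2cc(NNC(=O)Nc3cc(Cl)nc(Cl)c3)nc3c2cnn3C)cc1` differs from compound 1 only in methoxy in place of hydrogen on an aromatic carbon. Going by the values given here, no measured step bears directly on this change, so the expectation is a small shift, if any, in this assay, most likely toward a somewhat higher number. For compound 4 the estimate is 9000 nM, between 3000 nM and 27000 nM, expected as a 1.4-fold higher number from compound 1 to compound 4 (0.16 log units; within the scatter).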

Compound 4, half-maximal effective concentration: 12300 nM
Compound 4: middle estimate off by 1.4-fold (0.14 log units), on the low side; the range from low to high includes it.
By their numbers in this assay, from the lowest: compounds 1, 4 and 3 (each within the scatter of the next, the first and the last beyond it); then compound 2.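

For the compounds shown here, the first direct reading at this position is a 2.0-fold higher number from compound 1 to compound 4 (0.29 log units; within the scatter) in this assay. Methoxy, placed para to a large group on the six-membered aromatic ring, is therefore accepted here without a difference that can be told from the usual scatter. Nothing available explains this result. Still open, from the compounds shown here alone, is whether an amine, a carboxylic acid or a longer chain such as ethoxy at the same place would give a step beyond the scatter.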